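Swapping an amide for a sulfonamide on a shared scaffold

This account rests on a few compounds, and the source may have more. Where it says the series, first, only, none or still open, it means among the compounds named here.

Of the compounds shown here, three sharing one core have been measured in a functional assay on 143B cells (Homo sapiens) for antiproliferative activity, read by MTT assay, with a stated time of 48 h; a higher number here means a weaker inhibitor, a lower number a stronger inhibitor. Compound 1 `O=C(Nc1cccc(/C=C/C(=O)c2nc3ccccc3[nH]2)c1)c1ccccc1` gives 8340 nM. Compound 2 `O=C(Nc1cccc(/C=C/C(=O)c2nc3ccccc3[nH]2)c1)c1ccc(Cl)cc1`, which carries chloro in place of hydrogen on an aromatic carbon, gives 7440 nM, and a 1.1-fold lower number from compound 1 to compound 2 (0.05 log units; within the scatter). Compound 3 `Cc1cc(C)cc(C(=O)Nc2cccc(/C=C/C(=O)c3nc4ccccc4[nH]3)c2)c1` gives 4020 nM; a 2.1-fold lower number from compound 1 to compound 3 (0.32 log units; beyond the scatter), while a 1.9-fold lower number from compound 2 to compound 3 (0.27 log units; within the scatter). Compound 3 thus holds the lowest number of the three, set apart from compound 1 but not from compound 2.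

Compound 4 `O=C(/C=C/c1cccc(NS(=O)(=O)c2cccc(Cl)c2)c1)c1nc2ccccc2[nH]1` differs from compound 3 by one change: (3-chlorophenyl)sulfonyl in place of (3,5-dimethylphenyl)carbonyl on a nitrogen on an aromatic ring. Among the compounds with values here, no measured step bears directly on this exchange. The steps that touch the same end of the molecule are a 1.1-fold lower number from compound 1 to compound 2 (0.05 log units; within the scatter) and a 2.1-fold lower number from compound 1 to compound 3 (0.32 log units; beyond the scatter), both small or modest. Within the data shown here, because a 2.1-fold lower number from compound 1 to compound 3 (0.32 log units; beyond the scatter) was the only step beyond the scatter and that group now leaves, the expectation is that some of that gain is given back, but no step beyond the scatter is expected in this assay. The estimated step is a 1.5-fold higher number from compound 3 to compound 4 (0.17 log units; within the scatter). For compound 4 the expected value in this assay is 6000 nM, within a range from 2500 nM to 15000 nM.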

Compound 4, half-maximal inhibitory concentration: 2510 nM
Beside the measured number, compound 4's estimate is 2.4-fold (0.38 log units) above it; the range from low to high includes it.
By their numbers in this assay, from the lowest: compounds 4, 3, 2 and 1 (each within the scatter of the next, the first and the last beyond it).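

At this nitrogen on an aromatic ring, a sulfonyl link can stand in place of the carbonyl link with no loss in this assay: the exchange gives a 1.6-fold lower number from compound 3 to compound 4 (0.20 log units; within the scatter), so the two compounds cannot be told apart. Set against the other two amides, the picture is sharper, with a 3.0-fold lower number from compound 2 to compound 4 (0.47 log units; beyond the scatter) and a 3.3-fold lower number from compound 1 to compound 4 (0.52 log units; beyond the scatter), both modest but larger than any step among the carbonyl compounds, so the (3-chlorophenyl)sulfonyl group extends the range of this position without a clear gain over the (3,5-dimethylphenyl)carbonyl group. Nothing at hand gives a reason for these steps.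

Each of these exchanges alters the link and the ring substituents together, so the share of the sulfonyl itself and the share of the chloro group cannot be separated from these compounds alone. As far as these compounds go, a (3-chlorophenyl)carbonyl group or a (3,5-dimethylphenyl)sulfonyl group would divide the two, and it remains open how an unsubstituted phenylsulfonyl group, or an amine or carboxylic acid on that ring, would read in this assay.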